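This account rests on a few compounds, and the source may have more. Where it says the series, first, only, none or still open, it means among the compounds named here.

Of the compounds shown here, three sharing one core have been tested in a functional assay on EC9706 cells (Homo sapiens) for cytotoxicity, read by MTT assay, with a stated time of 72 h; a higher number here means a weaker inhibitor, a lower number a stronger inhibitor. Compound 1 `CC(C)NC(=O)N1CCN(C(=S)SCc2cn(Cc3ccc(F)cc3)nn2)CC1` gives 12200 nM. Compound 2 `CCN(C)C(=O)N1CCN(C(=S)SCc2cn(Cc3ccc(F)cc3)nn2)CC1` gives 14300 nM. Compound 3 `Cc1ccc(Cn2cc(CSC(=S)N3CCN(C(=O)NC(C)C)CC3)nn2)cc1` gives > 128000 nM, which is a limit of the assay and not a number; this is the limit of > 128000 nM in this assay, at which 1 of the 3 values shown sits.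

Two single changes connect these compounds. Between compound 1 and compound 2 the change is ethyl(methyl)amino in place of isopropylamino on a carbonyl carbon, and the outcome was a 1.2-fold higher number from compound 1 to compound 2 (0.07 log units; within the scatter). Between compound 1 and compound 3 the outcome was an at least 10-fold higher number from compound 1 to compound 3 (1.02 log units; beyond the scatter), so that the value of compound 3 can be given only as a limit.

Compound 4 `CCN(C)C(=O)N1CCN(C(=S)SCc2cn(Cc3ccc(C)cc3)nn2)CC1` has not yet been measured. It differs from compound 3 by ethyl(methyl)amino in place of isopropylamino on a carbonyl carbon, the same change that turned compound 1 into compound 2, made at the same place. The two cores on which this change is made differ from one another by methyl in place of fluoro on an aromatic carbon.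

The expected step here is a step that the limit leaves unreadable from compound 3 to compound 4, because a 1.2-fold higher number from compound 1 to compound 2 (0.07 log units; within the scatter) stayed within the scatter and the same change is now repeated on the core of compound 3, whose own value is already a limit. Compound 4 is therefore estimated at 160000 nM, with a range from 70000 nM to 400000 nM, and the measurement is expected most likely to return only a limit rather than a number.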

Compound 4, half-maximal inhibitory concentration: 70600 nM
Estimate against measurement, compound 4: 2.3-fold (0.36 log units) above, and the stated range covers the measured number.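

In this assay compound 3 gives > 128000 nM, which is a limit of the assay and not a number. Carrying the change from isopropylamino to ethyl(methyl)amino onto the core of compound 3 gives an at least 1.8-fold lower number from compound 3 to compound 4 (0.25 log units; that floor lies within the scatter), so the change made no measurable difference on the first core and a floor-only shift on the second, and the data do not show whether it truly behaves differently on the two cores: the same change on two cores in this assay, a 1.2-fold higher number (0.07 log units; within the scatter) from compound 1 to compound 2 and an at least 1.8-fold lower number (0.25 log units; that floor lies within the scatter) from compound 3 to compound 4; the limit leaves it open whether they differ Putting methyl in place of fluoro on an aromatic carbon raises the number on both pairs that share this swap, and on the ethyl(methyl)amino side it gives a 4.9-fold higher number from compound 2 to compound 4 (0.69 log units; beyond the scatter), so the direction holds across the two pairs shown, but the size of the effect cannot be compared between them: the same change on two cores in this assay, an at least 10-fold higher number (1.02 log units; beyond the scatter) from compound 1 to compound 3 and a 4.9-fold higher number (0.69 log units; beyond the scatter) from compound 2 to compound 4; the limit leaves it open whether they differ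

The compounds shown leave open how another group on that aromatic carbon, such as chloro or methoxy, would compare with fluoro and methyl. They also leave open whether a longer chain on the carbonyl carbon, such as diethylamino, would stay level with compound 1 and compound 2 or move away from them.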